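The source may report more compounds than this note shows. Statements on the series, on what has been measured and on what is new or still open speak of the compounds shown alone.

Measured so far:
- compound 1 `COc1ccc2[nH]c(=O)c(-c3nc4ccccc4[nH]3)cc2c1`: in a functional assay on NCI-H460 cells (Homo sapiens) for cytotoxicity, read by MTT assay, with a stated time of 48 h (on this read-out lower numbers stand for stronger inhibition and higher numbers for weaker inhibition), compound 1 gives > 100000 nM, a limit of the assay and not a number.
- compound 2 `Cc1cc2nc(-c3cc4ccccc4[nH]c3=O)[nH]c2cc1C`: compound 2 gives > 100000 nM, likewise a limit and not a number.
- compound 3 `O=c1[nH]c2ccccc2cc1-c1nc2cc(Br)ccc2[nH]1`: compound 3 gives 16800 nM.

Compound 2 therefore stands only at a limit in this assay, and it is not alone there: the limit of > 100000 nM in this assay, at which 2 of the 3 values shown sit. Only compound 3 gives a number at all. Within the data shown here, no step between measured compounds that differ in a single place exists in this set, so nothing here shows the size of any one change.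

The next compound, compound 4 `COc1ccc2[nH]c(=O)c(-c3nc4cc(C)c(C)cc4[nH]3)cc2c1`, differs from compound 2 by methoxy in place of hydrogen on an aromatic carbon. The same methoxy is already present in compound 1, and compound 1 sits at the limit just as compound 2 does. On that basis the step in this assay from compound 2 to compound 4 is expected to be none beyond the scatter, with no direction to favour; the expectation is that compound 4 also remains at the limit.

For compound 4 the estimate in this assay is 100000 nM, with a range from 30000 nM to 300000 nM, which as an expected step means a number no higher from compound 2 to compound 4 (the limit leaves the size open).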

Compound 4, half-maximal inhibitory concentration: > 100000 nM
Compound 4 ended at the assay's limit (the forecaster's own chance of this, stated with the estimate: 75%); the middle value sits exactly at the limit.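

No step can be read from compound 2 to compound 4, as both stand at a limit of the assay and neither gives a number: the limit of > 100000 nM in this assay, at which 3 of the 4 values shown sit.

Left open is whether methoxy in place of hydrogen on this aromatic carbon changes the value in this assay at all, and by how much.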